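The source may hold more compounds than are shown below. What is called first, only, known or untested is meant among the compounds shown, and "the series" means these compounds.

Compound 3 `O=C1c2cc(COc3ccc(F)cc3)nn2CCN1c1ccc(F)cc1` is one of three compounds built on a shared core that differ only in the aromatic ring attached to the oxygen on the saturated carbon. In a functional assay on HEK293 cells for positive allosteric modulation of metabotropic glutamate receptor 5 (Homo sapiens), read by calcium flux (a higher number here means a larger maximal response, a lower number a smaller maximal response), compound 3 gives 72%, the second highest of the three numbers. Compound 1 `O=C1c2cc(COc3ccccc3)nn2CCN1c1ccc(F)cc1` gives 79%, and compound 2 `O=C1c2cc(COc3ccccc3F)nn2CCN1c1ccc(F)cc1` gives 66%; both of these numbers lie within the usual scatter of the number for compound 3. Compound 4 `O=C1c2cc(COc3ccccn3)nn2CCN1c1ccc(F)cc1` has not yet been measured. It differs from compound 3 in one place: pyridin-2-yl in place of 4-fluorophenyl on an oxygen on a saturated carbon. The measured steps all concern a fluorine on this same ring: a number 13 percentage points lower from compound 1 to compound 2 (beyond the scatter), a number 7 percentage points lower from compound 1 to compound 3 (within the scatter) and a number 6 percentage points higher from compound 2 to compound 3 (within the scatter). Only one of them reached beyond the scatter, and none exchanges a ring carbon for a ring nitrogen, so they bear on the present change only loosely. A small step is expected, no change at the digits printed from compound 3 to compound 4 (within the scatter), with a wide range because a step such as a number 13 percentage points lower from compound 1 to compound 2 (beyond the scatter) shows that even a minor change at this ring can move the number. Compound 4 is therefore expected to give 72%, between 55% and 88%.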

Compound 4, largest response reached (Emax), in percent of the reference or control that the assay uses: 68%
The estimate for compound 4 lay 4 percentage points above the measured number; measured number inside the range.
By their numbers in this assay, from the lowest: compounds 2, 4, 3 and 1 (each within the scatter of the next, the first and the last beyond it).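

In this assay, for the compounds shown here, a ring nitrogen appears at this place for the first time, and exchanging 4-fluorophenyl for pyridin-2-yl gives a number 4 percentage points lower from compound 3 to compound 4 (within the scatter), while exchanging 2-fluorophenyl for it gives a number 2 percentage points higher from compound 2 to compound 4 (within the scatter), so the new ring cannot be told apart from either fluorinated ring. Against the plain phenyl ring, the exchange gives a number 11 percentage points lower from compound 1 to compound 4 (beyond the scatter), which places compound 4 with compound 2 as the two compounds set apart from compound 1, whereas compound 3 stays within the scatter of compound 1. Nothing measured here gives a reason for these numbers.

On these data alone, whether the position of the nitrogen in the ring matters remains open, and pyridin-3-yl or pyridin-4-yl would test this. Also open, as far as these compounds go, is how the response would change with an amine or a carboxylic acid on this ring, or with a longer chain carrying the oxygen.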